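The compounds below may be only part of what the source reports. "The series", "measured", "known", "first", "only" and "open" are said of these compounds alone.

Within the data shown here, in an ADME assay on microsomes from liver (Mus musculus, strain CD1) for metabolic stability, read by LC-MS, using NADPH, with a stated time of 60 min (on this read-out lower numbers stand for a shorter-lived compound and higher numbers for a longer-lived compound), compound 2 `COc1ccc(Cn2c(-c3ccccc3)c(-c3ccccc3)c3c(=N)n([C@H]4CC[C@H](O)CC4)cnc32)cc1` gives 2 h, the higher of the two numbers measured so far, and compound 1 `COc1ccc(Cn2c(-c3ccccc3)c(-c3ccccc3)c3c(=N)n(CC4CCOCC4)cnc32)cc1` gives 0.217 h. Compound 3 `COc1ccc(Cn2c(-c3ccccc3)c(-c3ccccc3)c3c(=N)n(CC4CCCO4)cnc32)cc1` has not yet been measured. It carries (oxolan-2-yl)methyl in place of the 4-hydroxycyclohexyl of compound 2 on an aromatic nitrogen: (oxolan-2-yl)methyl in place of 4-hydroxycyclohexyl on an aromatic nitrogen. Among the measured compounds shown here, one measured step bears on this change: 4-hydroxycyclohexyl in place of (oxan-4-yl)methyl gave a 9.2-fold higher number from compound 1 to compound 2 (0.96 log units; beyond the scatter). Like compound 1, compound 3 has a non-aromatic ring with an oxygen in the ring, joined through a methyl, and it has no hydrogen-bond donor in this group. A step of similar size in the opposite direction is therefore expected, although this rests on a single pair. In this assay the expected step is an 8.0-fold lower number from compound 2 to compound 3 (0.90 log units; beyond the scatter). For compound 3 the estimated half-life is 0.25 h, with an expected range of 0.1 h to 0.7 h.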

Compound 3, half-life: 0.157 h
The estimate for compound 3 lay 1.6-fold (0.20 log units) above the measured number, and the stated range covers the measured number.
By their numbers in this assay, from the lowest: compounds 3 and 1 (each within the scatter of the next); then compound 2.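

In this assay, replacing 4-hydroxycyclohexyl with a second ring ether joined through a methyl gives a 13-fold lower number from compound 2 to compound 3 (1.11 log units; beyond the scatter), so the gap to compound 2 no longer rests on (oxan-4-yl)methyl alone. Between the two ethers, ring size and the point of attachment change together and give a 1.4-fold lower number from compound 1 to compound 3 (0.14 log units; within the scatter), so within this pair neither change separates the compounds, and compound 2 alone stands apart among the three. Nothing available here accounts for the gap between compound 2 and the two ethers.

Compound 2 differs from both ethers in its hydroxyl, its all-carbon ring and its direct attachment to the aromatic nitrogen, and these features are not separated here. Going by these compounds, whether 4-methoxycyclohexyl, plain cyclohexyl or oxan-4-yl bound directly to that nitrogen would match compound 2 remains open.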